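The source may report more compounds than this note shows. Statements on the series, on what has been measured and on what is new or still open speak of the compounds shown alone.

Three compounds of the series have numbers in an assay on CHO cells for displacement of a labelled ligand from adenosine receptor A3 (Homo sapiens), read by scintillation counting, with a stated time of 3 h (a higher number here means a weaker inhibitor, a lower number a stronger inhibitor), so far. Compound 1 `Nc1nc(-c2ccco2)nc2sc(-c3ccccc3)nc12` gives 2.8 nM. Compound 2 `Nc1nc(-c2ccccc2)nc2sc(-c3ccco3)nc12`, which carries the same two aryl groups on exchanged positions, gives 15 nM. Compound 3 `Nc1nc(-c2cccc(O)c2)nc2sc(-c3ccco3)nc12` gives 15.7 nM, the highest of the three numbers, although its distance to compound 2 is within the scatter; only compound 1 stands apart from it beyond the scatter. Going by the values given here, the one single-point step measured, a 1.0-fold higher number from compound 2 to compound 3 (0.02 log units; within the scatter), shows that adding the hydroxy group changed nothing that can be trusted.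

Compound 4 `Nc1nc(-c2ccco2)nc2sc(-c3ccco3)nc12` is the next compound. Relative to compound 3 the change is furan-2-yl in place of 3-hydroxyphenyl on an aromatic carbon. Among the compounds with values here, no measured step covers the same replacement at that position, so the expectation rests on what the values of compound 1 and compound 2 show: the compound bearing furan-2-yl at that carbon, compound 1, gives the lower number, and the two compounds bearing a six-membered ring there give numbers close to each other. A moderate drop toward compound 1 is therefore expected for compound 4, estimated as a 3.1-fold lower number from compound 3 to compound 4 (0.50 log units; beyond the scatter). The estimate for compound 4 is 5 nM, with a range from 1.5 nM to 16 nM.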

Compound 4, inhibition constant: 99 nM
Compound 4: the middle estimate sits 20-fold (1.30 log units) below what was measured; measured number outside the range, above it.
By their numbers in this assay, from the lowest: compound 1; then compounds 2 and 3 (each within the scatter of the next); then compound 4.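

At the aromatic carbon between two ring nitrogen atoms, with furan-2-yl held on the other aryl-bearing carbon, the five-membered ring gives a higher number in this assay than either six-membered ring (phenyl: a 6.6-fold higher number from compound 2 to compound 4 (0.82 log units; beyond the scatter); 3-hydroxyphenyl: a 6.3-fold higher number from compound 3 to compound 4 (0.80 log units; beyond the scatter)), so this position distinguishes furan-2-yl from phenyl and 3-hydroxyphenyl, although the hydroxy group itself made no difference beyond the scatter. With furan-2-yl held at that carbon instead, the change on the other aromatic carbon from phenyl to furan-2-yl is the largest step in the series (a 35-fold higher number from compound 1 to compound 4 (1.55 log units; beyond the scatter)), so furan-2-yl at the carbon between the two ring nitrogen atoms goes with a low number only when phenyl sits on the other carbon, and the effect of a group at one position depends on the group at the other. Nothing shown accounts for either the size or the direction of these steps.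

The compounds shown leave open whether phenyl or 3-hydroxyphenyl at the carbon between the two ring nitrogen atoms would also give a higher or lower number with phenyl on the other carbon. They also leave open how an amine, a carboxylic acid or a longer chain on either aryl position would read in this assay.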